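The source may report more compounds than this note shows. Statements on the series, on what has been measured and on what is new or still open speak of the compounds shown alone.

Measured so far in a functional assay on HepG2 cells (Homo sapiens) for cytotoxicity, read by MTT assay, with a stated time of 24 h; on this read-out lower numbers stand for stronger inhibition and higher numbers for weaker inhibition:
- Compound 1 `CN1C/C(=C\c2ccncc2)C(=O)/C(=C/c2cc([N+](=O)[O-])ccc2F)C1`: 5200 nM
- Compound 2 `Cc1ccc(S(=O)(=O)N2C/C(=C\c3cccnc3)C(=O)/C(=C/c3ccccc3F)C2)cc1`: 4200 nM

Compound 2, at 4200 nM, and compound 1, at 5200 nM, lie within the usual scatter of each other, so these numbers do not separate the two. The next compound to test is compound 3 `N#Cc1ccc(S(=O)(=O)N2C/C(=C\c3cccnc3)C(=O)/C(=C/c3ccccc3F)C2)cc1`. It keeps compound 2 unchanged except for one place, para to a large group, turning 4-methylphenyl into 4-cyanophenyl: cyano in place of methyl on an aromatic carbon. Going by the values given here, no measured compound pair shows this change, so the data give no direction for it. In this assay, no shift beyond the scatter is therefore expected. The estimated step of a 1.1-fold lower number from compound 2 to compound 3 (0.04 log units; within the scatter) is correspondingly small. Compound 3 is expected at 3800 nM, with an estimated range from 1500 nM to 10000 nM.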

Compound 3, half-maximal inhibitory concentration: 6600 nM
The estimate for compound 3 lay 1.7-fold (0.24 log units) below the measured number, and the stated range covers the measured number.
By their numbers in this assay, from the lowest: compounds 2, 1 and 3 (each within the scatter of the next).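

Going by these compounds alone, compounds 2 and 3 form the one pair here that differs in a single place, so they give a direct reading of this change in this assay. Putting cyano in place of methyl on an aromatic carbon, para to a large group, gives a small step (a 1.6-fold higher number from compound 2 to compound 3 (0.20 log units; within the scatter)) that lies within the scatter. On these numbers, 4-methylphenyl and 4-cyanophenyl cannot be told apart at this position, and no measurement on hand offers an explanation for the result.

Going by these compounds, whether a group of another kind at this same place, such as an amine, a carboxylic acid or a methoxy group, would move the number beyond the scatter stays open. Also open, on these data alone, is whether the same exchange would read alike on a different core, such as that of compound 1.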